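Aryl amide variants on the shared core: compound 4

A few compounds are considered here, and "the series" means these few. Any claim that something is new, unique, unknown or untested is made for them only; others in the source may bear on it.

Measured in a functional assay on the whole organism for inhibition, with Rattus norvegicus as the target, read by cytopathic effect and paw edema, at a dose of 100 mg/kg by the oral route; a higher number here means more inhibition at the dose given (going by the name of the read-out), a lower number less inhibition:
- compound 1, `CNC(=O)c1c(O)c2cccnc2n(-c2ccccc2)c1=O`, gives 21%
- compound 2, `CN(C)CCNC(=O)c1c(O)c2cccnc2n(-c2ccccc2)c1=O`, gives 18.4%
- compound 3, `COc1ccc(NC(=O)c2c(O)c3cccnc3n(-c3ccccc3)c2=O)cc1`, gives -1.9%

Compound 3 stands lowest of the three numbers in this assay; its nearest neighbour is compound 2, a number 20.3 percentage points lower from compound 2 to compound 3 (beyond the scatter), and the furthest is compound 1, a number 22.9 percentage points lower from compound 1 to compound 3 (beyond the scatter). Between compound 1 and compound 2 the change on the amide-type nitrogen leaves the read-out essentially where it was, a number 2.6 percentage points lower from compound 1 to compound 2 (within the scatter).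

Compound 4, `Cc1cccc(NC(=O)c2c(O)c3cccnc3n(-c3ccccc3)c2=O)c1`, is the next variant on the amide-type nitrogen: 3-methylphenyl in place of 4-methoxyphenyl on an amide-type nitrogen.

Among the compounds with values here, no measured step swaps one aryl group for another at this position. The two steps that do bear on it, from compound 1 and from compound 2 into compound 3, both replace a small alkyl with an aryl group and both lower inhibition by a modest amount beyond the scatter. Compound 4 keeps the aryl group and changes only its substituent, so the expectation is a step from compound 3 of no size beyond the scatter, a number 4.9 percentage points higher from compound 3 to compound 4 (within the scatter), in either direction.

For compound 4 the expected read-out in this assay is therefore 3%, with a range from -15% to 20%.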

Compound 4, a percentage reported as inhibition, in the whole organism at one dose (the size of the read-out at that dose, not a potency): 4.5%
Estimate against measurement, compound 4: 1.5 percentage points below; the measured number falls inside the stated range.
By their numbers in this assay, from the lowest: compounds 3 and 4 (each within the scatter of the next); then compounds 2 and 1 (each within the scatter of the next).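

In this assay the swap of one aryl group for another on the amide-type nitrogen gives a number 6.4 percentage points higher from compound 3 to compound 4 (within the scatter) and so does not separate 3-methylphenyl from 4-methoxyphenyl, although only 4-methoxyphenyl carries an oxygen and a hydrogen-bond acceptor. The fall seen on replacing a small alkyl group with an aryl group recurs with this second aryl group (a number 16.5 percentage points lower from compound 1 to compound 4 (beyond the scatter); a number 13.9 percentage points lower from compound 2 to compound 4 (beyond the scatter)), so across these four compounds both aryl amides lie beyond the scatter from both alkyl amides, and none of the four goes against this. Nothing available accounts for either the flat aryl swap or the gap between aryl and alkyl amides.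

Still open, on these data alone, is whether an aryl group carrying a carboxylic acid or a primary amine, or a plain unsubstituted phenyl, would leave the read-out close to that of compound 3 and compound 4. Also open, as far as these compounds go, is whether a longer alkyl chain such as hexyl on the same nitrogen would stay close to compound 1 and compound 2 or fall toward the aryl amides.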